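This account rests on a few compounds, and the source may have more. Where it says the series, first, only, none or still open, it means among the compounds named here.

Compound 2, `N/C(=N\NC(=S)N1CCCC1)c1ccc(F)cn1`, is the weakest of the three measured compounds in a functional assay on MCF7 cells (Homo sapiens) for cytotoxicity, read by MTT assay, with a stated time of 72 h, tested at 30 uM; a higher number here means more inhibition of growth at the concentration tested, a lower number less inhibition of growth: compound 2 gives 60.6%. Compound 1, `N/C(=N\NC(=S)N1CCCCCC1)c1ccccn1`, gives 76.5% in this assay, and compound 3, `Cc1ccnc(/C(N)=N/NC(=S)N2CCCCCC2)c1`, gives 75.9%; both numbers lie beyond the scatter above the number for compound 2. Among the compounds with values here, the one directly comparable step, a number 0.6 percentage points lower from compound 1 to compound 3 (within the scatter), concerns the aromatic ring and not the amine ring of the thiourea part, so it says nothing about the change now at hand.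

Compound 4, `N/C(=N\NC(=S)N1CCSCC1)c1ccc(F)cn1`, differs from compound 2 by thiomorpholin-4-yl in place of pyrrolidin-1-yl on a thiocarbonyl carbon. Within the data shown here, no measured pair isolates a change of the amine ring; compounds 1 and 3 carry a different ring and a different aromatic part at once, so their values show only that another ring size can go with more growth inhibition. The step from compound 2 to compound 4 is therefore expected to be a number 2.4 percentage points higher from compound 2 to compound 4 (within the scatter), with little confidence in its direction. For compound 4 the estimate is 63%, within a range from 42% to 82%.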

Compound 4, percent growth inhibition at one concentration: 58.8%
Beside the measured number, compound 4's estimate is 4.2 percentage points above it; the range from low to high includes it.
By their numbers in this assay, from the lowest: compounds 4 and 2 (each within the scatter of the next); then compounds 3 and 1 (each within the scatter of the next).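

In this assay the amine ring on the thiocarbonyl carbon changes while the rest of the structure stays the same, and this gives a number 1.8 percentage points lower from compound 2 to compound 4 (within the scatter) as the result of the exchange. This pair is the only one shown that isolates this position, and it shows that thiomorpholin-4-yl, a six-membered ring with 2 hetero atoms, can stand in place of pyrrolidin-1-yl, a five-membered ring with 1 hetero atom, without a change that can be told from the scatter. Nothing measured here offers an explanation for this result.

The compounds shown leave open whether morpholin-4-yl, piperazin-1-yl or an open-chain dimethylamino group on this carbon would move the number beyond the scatter. They also leave open whether thiomorpholin-4-yl would give a similar outcome on the aromatic part of compound 1.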